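Dimethylamino Replaces (Pentylcarbonyl)oxy on the Side Arm

This account rests on a few compounds, and the source may have more. Where it says the series, first, only, none or still open, it means among the compounds named here.

Of the compounds shown here, three sharing one core have been tested in a functional assay on MCF7 cells (Homo sapiens) for cytotoxicity, read by neutral red uptake, with a stated time of 3 days; a lower number here means a stronger inhibitor, a higher number a weaker inhibitor. Compound 1 `CCc1c(F)c(N)c2c(=O)cc(-c3ccc(N)c(F)c3)oc2c1F` gives 130 nM, compound 2 `CCCCc1c(F)c(N)c2c(=O)cc(-c3ccc(N)c(F)c3)oc2c1F` gives 8800 nM, and compound 3 `CCCCCC(=O)OCc1c(F)c(N)c2c(=O)cc(-c3ccc(N)c(F)c3)oc2c1F` gives 160 nM. Compound 3 thus stands second highest of the three numbers: its step of a 1.2-fold higher number from compound 1 to compound 3 (0.09 log units; within the scatter) lies within the scatter, while a 55-fold lower number from compound 2 to compound 3 (1.74 log units; beyond the scatter) is large. The next compound, compound 4 `CN(C)Cc1c(F)c(N)c2c(=O)cc(-c3ccc(N)c(F)c3)oc2c1F`, differs from compound 3 in one place: dimethylamino in place of (pentylcarbonyl)oxy on a saturated chain carbon bound to an aromatic carbon. Two measured steps alter the same saturated chain carbon bound to an aromatic carbon, and they differ greatly in size: a 1.2-fold higher number from compound 1 to compound 3 (0.09 log units; within the scatter) is small, whereas a 55-fold lower number from compound 2 to compound 3 (1.74 log units; beyond the scatter) is large. Among the compounds with values here, no measured step brings in a dimethylamino group, so the expectation rests only on the observation that compound 1 and compound 3 give similar numbers. Compound 4 is therefore expected to remain near the lower numbers of this set. For compound 4 the expected step is a 1.6-fold higher number from compound 3 to compound 4 (0.19 log units; within the scatter). The estimated value for compound 4 in this assay is 250 nM, within a range from 50 nM to 1500 nM.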

Compound 4, half-maximal inhibitory concentration: 72 nM
Beside the measured number, compound 4's estimate is 3.5-fold (0.54 log units) above it; the measured number falls inside the stated range.
By their numbers in this assay, from the lowest: compounds 4, 1 and 3 (each within the scatter of the next, the first and the last beyond it); then compound 2.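

Dimethylamino is the first group shown on this saturated chain carbon bound to an aromatic carbon that carries a nitrogen, and in this assay replacing (pentylcarbonyl)oxy with it gives a 2.2-fold lower number from compound 3 to compound 4 (0.35 log units; beyond the scatter), a modest gain despite the swap of 8 heavy atoms for 3. Against the propyl of compound 2 the change is large, with a 120-fold lower number from compound 2 to compound 4 (2.09 log units; beyond the scatter), whereas a 1.8-fold lower number from compound 1 to compound 4 (0.26 log units; within the scatter) leaves dimethylamino level with the methyl of compound 1, so among these four compounds propyl alone stands apart from the other three groups at this place. No measurement shown explains why these groups differ.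

From the compounds shown here alone, whether a larger amine such as diethylamino or a ring amine such as morpholine would keep the number this low remains open. So does the effect of a carboxylic acid on this chain carbon.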